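Oxime ether series: chloro for fluoro on the bromo core

This account rests on a few compounds, and the source may have more. Where it says the series, first, only, none or still open, it means among the compounds named here.

Measured so far in a functional assay on A549 cells (Homo sapiens) for antiproliferative activity, read by MTT assay, with a stated time of 48 h; a higher number here means a weaker inhibitor, a lower number a stronger inhibitor:
compound 1 `O=[N+]([O-])c1cc(C(F)(F)F)cc([N+](=O)[O-])c1Oc1ccccc1/C=N\OCc1ccccc1F` gives 860 nM
compound 2 `O=[N+]([O-])c1cc(C(F)(F)F)cc([N+](=O)[O-])c1Oc1ccccc1/C=N/OCc1ccccc1Cl` gives 1430 nM
compound 3 `O=[N+]([O-])c1cc(C(F)(F)F)cc([N+](=O)[O-])c1Oc1ccc(Br)cc1/C=N\OCc1ccccc1F` gives 1280 nM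

The change a group of 11 heavy atoms (8 carbon, 1 nitrogen, 1 oxygen, 1 chlorine; one six-membered aromatic ring of carbon only) in place of a group of 11 heavy atoms (8 carbon, 1 nitrogen, 1 oxygen, 1 fluorine; one six-membered aromatic ring of carbon only), on an aromatic carbon gave a step of a 1.7-fold higher number from compound 1 to compound 2 (0.22 log units; within the scatter) in this assay. The bromo change bromo in place of hydrogen on an aromatic carbon gave a 1.5-fold higher number from compound 1 to compound 3 (0.17 log units; within the scatter). Compound 4 `O=[N+]([O-])c1cc(C(F)(F)F)cc([N+](=O)[O-])c1Oc1ccc(Br)cc1/C=N/OCc1ccccc1Cl` carries the same kind of change as compound 1 to compound 2, (a group of 11 heavy atoms (8 carbon, 1 nitrogen, 1 oxygen, 1 chlorine; one six-membered aromatic ring of carbon only) in place of a group of 11 heavy atoms (8 carbon, 1 nitrogen, 1 oxygen, 1 fluorine; one six-membered aromatic ring of carbon only), on an aromatic carbon), but now meta to a bromo group and on the core of compound 3. Among the measured compounds shown here, both earlier steps sat within the scatter, so no real shift is expected here either; the estimate for compound 4 is 2000 nM (range 900 nM to 4500 nM), a step of a 1.6-fold higher number from compound 3 to compound 4 (0.19 log units; within the scatter) from compound 3, resting only on the single earlier step of a 1.7-fold higher number from compound 1 to compound 2 (0.22 log units; within the scatter).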

Compound 4, half-maximal inhibitory concentration: 3430 nM
Compound 4: middle estimate off by 1.7-fold (0.23 log units), on the low side, and the stated range covers the measured number.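

In this assay, the chlorine-bearing group in place of the fluorine-bearing group gives a 2.7-fold higher number from compound 3 to compound 4 (0.43 log units; beyond the scatter), in the same direction as on the core of compound 1, and the two steps do not differ beyond the scatter: the same change on two cores in this assay, a 1.7-fold higher number (0.22 log units; within the scatter) from compound 1 to compound 2 and a 2.7-fold higher number (0.43 log units; beyond the scatter) from compound 3 to compound 4, 1.6-fold (0.21 log units) apart, within the scatter of two such steps. Bromo in place of hydrogen likewise gives a 2.4-fold higher number from compound 2 to compound 4 (0.38 log units; beyond the scatter), again matching its earlier step: the same change on two cores in this assay, a 1.5-fold higher number (0.17 log units; within the scatter) from compound 1 to compound 3 and a 2.4-fold higher number (0.38 log units; beyond the scatter) from compound 2 to compound 4, 1.6-fold (0.21 log units) apart, within the scatter of two such steps. The swap therefore carries across these two cores in direction and, within the scatter, in size, but the steps lying on different sides of the scatter do not show a larger effect on the bromo core, and two pairs give no rule for other cores.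

The swap also alters the drawn geometry at the oxime double bond, so the compounds shown do not separate the halogen from that geometry. Also open, as far as these compounds go, is how a methoxy group or an amine in place of the halogen would read on either core.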